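This account rests on a few compounds, and the source may have more. Where it says the series, first, only, none or still open, it means among the compounds named here.

Measured compounds:
Compound 1, `Nc1ccccc1NC(=O)/C=C/c1cn([C@H]2C[C@@H](C(=O)O)N(CCCc3ccccc3)C2)nn1`: < 10%
Compound 2, `Nc1ccccc1NC(=O)/C=C/c1cn([C@@H]2C[C@@H](C(=O)O)N(Cc3ccccc3)C2)nn1`: < 10%

In an assay on cells for inhibition of histone deacetylase 11 (Homo sapiens), read by fluorescence, with stated times of 3 h and 30 min, tested at 2 uM, in the presence of a further agent that is not named here (on this read-out higher numbers stand for more inhibition at the one concentration tested (going by the name of the read-out) and lower numbers for less inhibition), compound 1 gives < 10%, which is a limit of the assay rather than a number. In this assay compound 2 gives < 10%, again a limit of the assay. Compound 2 thus sits at the limit of < 10% in this assay, at which 2 of the 2 values shown sit, and on these numbers nothing separates it from compound 1.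

Compound 3, `Nc1ccccc1NC(=O)/C=C/c1cn([C@@H]2C[C@@H](C(=O)O)N(CCCc3ccccc3)C2)nn1`, is not yet measured in this assay. It differs from compound 2 in one place: phenethyl in place of phenyl on a saturated chain carbon bound to an amine nitrogen in a ring. Among the measured compounds shown here, no step between measured compounds is available, so the size of this change cannot be read from the data. The point of departure is the limit < 10% of compound 2. From there the step that the limit leaves unreadable from compound 2 to compound 3 is expected to be none beyond the scatter, with the value most likely remaining a limit. Compound 3 is estimated at 5%, between 0% and 15%.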

Compound 3, a percentage reported as inhibition, at one concentration (the size of the read-out at that concentration, not a potency): < 10%
Compound 3: only a limit was reported; the forecaster's own chance of this, stated with the estimate: 85%; the middle value is on the limit's open side.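

In this assay, among the compounds shown here, compound 3 gives < 10%, a limit of the assay, so no step to compound 3 from compound 1 or compound 2 can be read. The compounds shown leave open whether the change from benzyl to 3-phenylpropyl or the drawn configuration affects inhibition at all, as all share one limit: the limit of < 10% in this assay, at which 3 of the 3 values shown sit.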